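Ring-nitrogen group: carbonyl replaced by sulfonyl

The source may report more compounds than this note shows. Statements on the series, on what has been measured and on what is new or still open speak of the compounds shown alone.

Three compounds share one core and differ only at the amine nitrogen in the ring. Compound 1 `C(#Cc1nc2c(s1)CN(C1CCCCC1)CC2)c1ccccc1` carries a cyclohexyl group there; in an assay on HEK293 cells for positive allosteric modulation of metabotropic glutamate receptor 5 (Homo sapiens), read by FLIPR, with a stated time of 1 h (a higher number here means that more compound is needed for the effect, a lower number that less compound is needed), compound 1 gives > 10000 nM, a limit of the assay and not a number. Compound 2 `O=C(C1CC1)N1CCc2nc(C#Cc3ccccc3)sc2C1` carries a cyclopropylcarbonyl group; in this assay compound 2 gives > 10000 nM, again a limit. Going by the values given here, compound 3 `O=C(C1CCCCO1)N1CCc2nc(C#Cc3ccccc3)sc2C1` carries an (oxan-2-yl)carbonyl group and in this assay gives 320 nM, the only number in the set. The steps were an at least 31-fold lower number from compound 1 to compound 3 (1.49 log units; beyond the scatter) and an at least 31-fold lower number from compound 2 to compound 3 (1.49 log units; beyond the scatter); the step that the two limits leave unreadable from compound 1 to compound 2 stays unreadable, as the limit of > 10000 nM in this assay, at which 2 of the 3 values shown sit, shows.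

Compound 4 `O=S(=O)(C1CC1)N1CCc2nc(C#Cc3ccccc3)sc2C1` is not yet measured. The change is cyclopropylsulfonyl in place of (oxan-2-yl)carbonyl on an amine nitrogen in a ring. Among the compounds with values here, the nearest measured step is an at least 31-fold lower number from compound 2 to compound 3 (1.49 log units; beyond the scatter), where cyclopropylcarbonyl sat at the limit; compound 4 keeps the cyclopropyl ring but on a sulfonyl rather than a carbonyl, and no measured step covers a sulfonyl. The number for compound 4 is therefore expected to rise, the step of a 9.4-fold higher number from compound 3 to compound 4 (0.97 log units; beyond the scatter) being the expectation, with a real chance that only the limit is read. For compound 4 the estimate is 3000 nM, with a range from 700 nM to 12000 nM.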

Compound 4, half-maximal effective concentration: > 10000 nM
Compound 4 ended at the assay's limit; the forecaster's own chance of this, stated with the estimate: 40%; middle value at least 3.3-fold (0.52 log units) from the limit.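

Going by these compounds alone, replacing (oxan-2-yl)carbonyl with cyclopropylsulfonyl on the amine nitrogen in the ring gives, in this assay, an at least 31-fold higher number from compound 3 to compound 4 (1.49 log units; beyond the scatter), so the one readable number at this position does not survive this change. The change swaps the carbonyl for a sulfonyl and the oxan-2-yl ring for a cyclopropyl ring at once, and this step alone cannot divide the loss between the two. The steps to compound 4 from compound 1 and from compound 2 cannot be read, so the swap of carbonyl for sulfonyl on a cyclopropyl ring has no size: the limit of > 10000 nM in this assay, at which 3 of the 4 values shown sit.

Open, on these data alone, is whether an (oxan-2-yl)sulfonyl group on the same nitrogen would stay near compound 3 at 320 nM, which would show the sulfonyl on its own against the same ring. Also open, as far as these compounds go, is whether the oxygen of the oxan-2-yl ring is needed at all, which a cyclohexylcarbonyl group or an open chain such as pentanoyl would test.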